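A few compounds are considered here, and "the series" means these few. Any claim that something is new, unique, unknown or untested is made for them only; others in the source may bear on it.

Measured compounds in a functional assay on K562 cells (Homo sapiens) for inhibition, read by MTT assay, with a stated time of 72 h; on this read-out higher numbers stand for weaker inhibition and lower numbers for stronger inhibition:
compound 1 `Cc1ccc(-c2cn(-c3ccc(CN4CCN(C)CC4)cc3)nn2)cc1Nc1nccc(-c2cccnc2)n1` gives 4700 nM
compound 2 `Cc1ccc(-n2cc(-c3ccc(CN4CCN(C)CC4)c(C(F)(F)F)c3)nn2)cc1Nc1nccc(-c2cccnc2)n1` gives 40 nM
compound 3 `COc1ccc(-c2cn(-c3ccc(C)c(Nc4nccc(-c5cccnc5)n4)c3)nn2)cc1C(F)(F)F` gives 11200 nM

Compound 3 holds the highest number of the three in this assay, with compound 1 nearest and compound 2 furthest from it. For the measured compounds named here, the only single-point step recorded is a 280-fold higher number from compound 2 to compound 3 (2.45 log units; beyond the scatter). Compound 4 `Cc1ccc(-n2cc(CCCCO)nn2)cc1Nc1nccc(-c2cccnc2)n1` differs from compound 3 by 4-hydroxybutyl in place of 4-methoxy-3-(trifluoromethyl)phenyl on an aromatic carbon. No measured step removes the aryl group at that position, so nothing shown bears directly on this change; the change replaces the whole group that the step from compound 2 to compound 3 merely modified. The expectation for compound 4 therefore rests on weak precedent and is expected to be a 1.1-fold higher number from compound 3 to compound 4 (0.03 log units; within the scatter) in this assay, with wide uncertainty. Compound 4 is estimated at 12000 nM, within 3000 nM to 50000 nM.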

Compound 4, half-maximal inhibitory concentration: 11200 nM
Compound 4: the middle estimate sits 1.1-fold (0.03 log units) above what was measured, within the range that was stated.
By their numbers in this assay, from the lowest: compound 2; then compound 1; then compounds 3 and 4 (each within the scatter of the next).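

In this assay, putting 4-hydroxybutyl in place of 4-methoxy-3-(trifluoromethyl)phenyl gives no change at the digits printed from compound 3 to compound 4 (within the scatter). The earlier compounds shown here varied only the substituents on a six-membered aromatic ring at this position; this step shows that an open chain with no ring can stand there with the number staying within the scatter of that of compound 3. Nothing available explains this result.

On these data alone, whether an amine or a carboxylic acid at the end of the chain, or a longer chain, would shift the number remains open.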